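A few compounds are considered here, and "the series" means these few. Any claim that something is new, unique, unknown or untested is made for them only; others in the source may bear on it.

Compound 2 `CC(C)(C)C(=O)N(CCCCCCN1C[C@H](O)[C@@H](O)[C@H](O)[C@H]1CO)C1CCCCCC1` stands only at a limit of the assay. In an ADME assay on MDBK cells (Bos taurus) for cytotoxicity, read by MTT assay (on this read-out higher numbers stand for lower toxicity in this test and lower numbers for higher toxicity in this test), compound 2 gives > 500000 nM, a limit rather than a number. Compound 1 `CC(C)(C)C(=O)N(CCCCCCN1C[C@H](O)[C@@H](O)[C@H](O)[C@H]1CO)c1cc(F)ccc1F` likewise reaches only a limit. In this assay compound 1 gives > 500000 nM. The step that the two limits leave unreadable from compound 1 to compound 2 is therefore unreadable, and the limit of > 500000 nM in this assay, at which 2 of the 2 values shown sit, shows both values resting at the same limit. Compound 3 `CC(C)(C)C(=O)N(CCCCCCN1C[C@H](O)[C@@H](O)[C@H](O)[C@H]1CO)C1CCCCCCC1` differs from compound 2 by cyclooctyl in place of cycloheptyl on an amide-type nitrogen. Among the measured compounds shown here, no measured step bears on this change with a readable size. For compound 3 a limit again is expected, estimated at 500000 nM with a range of 250000 nM to 1000000 nM. The step of a number no higher from compound 2 to compound 3 (the limit leaves the size open) is expected to be none beyond the scatter.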

Compound 3, half-maximal cytotoxic concentration: 270000 nM
Compound 3: middle estimate off by 1.9-fold (0.27 log units), on the high side, and the stated range covers the measured number.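

Among the compounds shown here, compound 3 is the first of the series to give a number rather than a limit in this assay, so a cyclooctyl on this amide-type nitrogen brings the read-out inside the measurable range. Cycloheptyl to cyclooctyl gives an at least 1.8-fold lower number from compound 2 to compound 3 (0.26 log units; that floor lies within the scatter), and 2,5-difluorophenyl to cyclooctyl gives an at least 1.8-fold lower number from compound 1 to compound 3 (0.26 log units; that floor lies within the scatter); both are floors, so the true sizes stay open. The other two compounds still give no number: the limit of > 500000 nM in this assay, at which 2 of the 3 values shown sit.

From the compounds shown here alone, whether a cyclohexyl or an unsubstituted phenyl on this nitrogen would give a number in this assay remains open. So does the reading for a larger carbocycle, such as cyclodecyl, in the same place.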